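The compounds below may be only part of what the source reports. "The series", "measured", "known", "first", "only" and "open" are said of these compounds alone.

Compound 2 `Cc1cc(-c2nc(C(F)(F)F)ccc2CNC(=O)C(C)c2ccc(NS(C)(=O)=O)c(F)c2)ccc1F` gives 0.4 nM in an assay on CHO cells for antagonist activity at transient receptor potential cation channel subfamily V member 1 (Homo sapiens), read by FLIPR; a higher number here means a weaker inhibitor, a lower number a stronger inhibitor. Compound 1 `CC(C(=O)NCc1ccc(C(F)(F)F)nc1-c1ccc(N(C)C)cc1)c1ccc(NS(C)(=O)=O)c(F)c1` gives 3.2 nM. Compound 3 `CC(C(=O)NCc1ccc(C(F)(F)F)nc1-c1ccc2cc[nH]c2c1)c1ccc(NS(C)(=O)=O)c(F)c1` gives 20.3 nM.

Compound 2 has the lowest number of the three and is the strongest inhibitor here: an 8.0-fold lower number from compound 1 to compound 2 (0.90 log units; beyond the scatter) and a 51-fold higher number from compound 2 to compound 3 (1.71 log units; beyond the scatter) both lie beyond the scatter. Compound 4 `CC(C(=O)NCc1ccc(C(F)(F)F)nc1/C=C/c1ccccc1)c1ccc(NS(C)(=O)=O)c(F)c1` differs from compound 2 in that one group: 2-phenylethenyl in place of 4-fluoro-3-methylphenyl on an aromatic carbon. The two measured steps show that exchanging this group moves the number by modest to large amounts, and compound 2 already holds the best value, so a further exchange is more likely to raise the number than to lower it. Compound 4 is therefore expected to be a weaker inhibitor than compound 2, by about a 7.5-fold higher number from compound 2 to compound 4 (0.88 log units; beyond the scatter). The estimate for compound 4 in this assay is 3 nM, with a range from 0.5 nM to 20 nM.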

Compound 4, inhibition constant: 2.2 nM
Compound 4: the middle estimate sits 1.4-fold (0.13 log units) above what was measured; the range from low to high includes it.
By their numbers in this assay, from the lowest: compound 2; then compounds 4 and 1 (each within the scatter of the next); then compound 3.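

The earlier groups at this position all joined their ring directly to the aromatic carbon, so compound 4 adds something new: in this assay, a ring carried on a double bond is tolerated, matching the 4-(dimethylamino)phenyl group within the scatter (a 1.5-fold lower number from compound 1 to compound 4 (0.16 log units; within the scatter)). The 2-phenylethenyl group still falls short of 4-fluoro-3-methylphenyl (a 5.5-fold higher number from compound 2 to compound 4 (0.74 log units; beyond the scatter)) but outperforms 1H-indol-6-yl (a 9.2-fold lower number from compound 3 to compound 4 (0.97 log units; beyond the scatter)). No measurement available here explains these differences.

Open, as far as these compounds go, is how a 2-phenylethyl chain, with the double bond saturated, or a 2-phenylethenyl group bearing a fluorine on its ring would compare with compound 4.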